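Moving the Fluorine on the Aryl Sulfonyl Group

This account rests on a few compounds, and the source may have more. Where it says the series, first, only, none or still open, it means among the compounds named here.

Compound 1 `COc1ccccc1N1CCN(CC[C@H]2CCCN2S(=O)(=O)c2ccc(F)cc2)CC1` gives > 10000 nM in an assay on CHO cells for displacement of a labelled ligand from 5-hydroxytryptamine receptor 6 (Homo sapiens); a lower number here means a stronger inhibitor, a higher number a weaker inhibitor; this is a limit of the assay, not a number.
Compound 2 `CC1CCN(CC[C@H]2CCCN2S(=O)(=O)c2ccc(F)cc2)CC1` gives > 10000 nM in this assay; this too is a limit of the assay, not a number.

Compound 2 stands at the limit of > 10000 nM in this assay, at which 2 of the 2 values shown sit. Neither measured compound yields an actual number, so all that is known is that both displace the labelled ligand weakly, if at all, and no ordering between them can be drawn. Among the measured compounds shown here, no pair of measured compounds differs in a single place, so there is no measured step whose size could guide an expectation.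

Compound 3 `CC1CCN(CC[C@H]2CCCN2S(=O)(=O)c2ccccc2F)CC1` has not yet been measured. It differs from compound 2 by 2-fluorophenyl in place of 4-fluorophenyl on a sulfonyl sulfur. With the starting point already at the limit, the expected step that the limit leaves unreadable from compound 2 to compound 3 is small and most likely none beyond the usual scatter. Compound 3 is therefore expected to give about 12000 nM in this assay, within a range of 3000 nM to 50000 nM, and will probably again be reported only as a limit rather than a number.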

Compound 3, antagonist equilibrium constant: > 10000 nM
Compound 3: no number, only a limit; the forecaster's own chance of this, stated with the estimate: 75%; the middle value does not contradict the limit.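

Compound 2 and compound 3 both give a limit of the assay rather than a number, so no step can be read for 2-fluorophenyl in place of 4-fluorophenyl. The same holds across the series: the limit of > 10000 nM in this assay, at which 3 of the 3 values shown sit.

The compounds shown leave open how strongly any of them acts in this assay, and which change to the shared core would yield a real number.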